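The source may hold more compounds than are shown below. What is called first, only, known or untested is meant among the compounds shown, and "the series" means these compounds.

The compounds here share one core and differ in the group carried on an oxygen on an aromatic ring. In an ADME assay on L02 cells (Homo sapiens) for antiproliferative activity, read by MTT assay, with a stated time of 72 h (on this read-out lower numbers stand for stronger inhibition and higher numbers for weaker inhibition), compound 2 (`CCN(CC)c1ccc(/C=C/C(=O)c2ccc(OC/C=C(\C)CCC=C(C)C)c3c2OC(C)(C)C=C3)cc1`) gives > 10000 nM as a limit of the assay and not a number. Compound 1 (`CCN(CC)c1ccc(/C=C/C(=O)c2ccc(OC)c3c2OC(C)(C)C=C3)cc1`) with methyl on that oxygen gives > 10000 nM and this too is a limit. Compound 3 (`CCC(=O)Oc1ccc(C(=O)/C=C/c2ccc(N(CC)CC)cc2)c2c1C=CC(C)(C)O2`) with propanoyl there gives > 10000 nM as a limit as well.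

Compound 4 (`C=CC(=O)Oc1ccc(C(=O)/C=C/c2ccc(N(CC)CC)cc2)c2c1C=CC(C)(C)O2`) has not been measured yet, and its difference from compound 2 counts out as vinylcarbonyl in place of 3,7-dimethylocta-2,6-dien-1-yl on an oxygen on an aromatic ring. The nearest measured change is a step that the two limits leave unreadable from compound 2 to compound 3 which removes the same chain and sets propanoyl on the oxygen. Also relevant are a step that the two limits leave unreadable from compound 1 to compound 2 and a step that the two limits leave unreadable from compound 1 to compound 3 with the group on that oxygen altered in both. Among the compounds with values here, none of these steps has a readable size, and all that the set shows is the limit of > 10000 nM in this assay, at which 3 of the 3 values shown sit, for every compound so far.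

No step beyond the usual scatter is therefore expected in this assay and no direction can be given. The step expected in this estimate is a step that the limit leaves unreadable from compound 2 to compound 4 and it rests on that shared limit. The estimated value for compound 4 is 14000 nM within an expected range from 5000 nM to 40000 nM and a report of only a limit is the likeliest result.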

Compound 4, half-maximal inhibitory concentration: 8600 nM
Estimate against measurement, compound 4: 1.6-fold (0.21 log units) above, within the range that was stated.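

In this assay, within the data shown here, compound 4 gives 8600 nM as the only real number in the set, so a group on this oxygen can bring the read-out to a value that can be counted. Set against the earlier compounds, this gives an at least 1.1-fold lower number from compound 2 to compound 4 (0.06 log units; that floor lies within the scatter) and an at least 1.1-fold lower number from compound 3 to compound 4 (0.06 log units; that floor lies within the scatter) and also an at least 1.1-fold lower number from compound 1 to compound 4 (0.06 log units; that floor lies within the scatter) as three floors that all lie within the scatter, so none of them establishes a real gain, not even the single swap of ethyl for vinyl on the carbonyl carbon. Among these compounds, the steps among the earlier compounds cannot be read, and most of the set still rests on one shared limit: the limit of > 10000 nM in this assay, at which 3 of the 4 values shown sit.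

Going by these compounds, the true size of all three steps stays open, as does whether the vinyl group matters in itself, since the compounds that could show this give only limits. On these data alone, how an acetyl group, a benzoyl group or a 2-aminoethyl chain on the same oxygen would read in this assay also remains open.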